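The source may hold more compounds than are shown below. What is called first, only, known or untested is meant among the compounds shown, and "the series" means these compounds.

Compound 1 `O=C(Nc1cccc(Cl)c1)C(Cl)Cl`: 44500 nM
Compound 2 `COc1cccc(NC(=O)C(Cl)Cl)c1`: 54800 nM
Compound 3 `O=C(Nc1cccc(C(F)(F)F)c1)C(Cl)Cl`: 5970 nM

These three numbers come from a functional assay on Bel-7402 cells (Homo sapiens) for antiproliferative activity, read by MTT assay, with a stated time of 72 h; a higher number here means a weaker inhibitor, a lower number a stronger inhibitor. Compound 3 stands lowest of the three: the step of a 7.5-fold lower number from compound 1 to compound 3 (0.87 log units; beyond the scatter) and the step of a 9.2-fold lower number from compound 2 to compound 3 (0.96 log units; beyond the scatter) both lie beyond the scatter, whereas a 1.2-fold higher number from compound 1 to compound 2 (0.09 log units; within the scatter) does not. Compound 4 `O=C(Nc1cccc(SC(F)(F)F)c1)C(Cl)Cl` differs from compound 3 by (trifluoromethyl)sulfanyl in place of trifluoromethyl on an aromatic carbon. Among the compounds with values here, no measured step places a (trifluoromethyl)sulfanyl group anywhere, so the steps that reach compound 3 bear on this change only loosely; they show that swapping the group on this aromatic carbon has moved the number by modest amounts. A step of no more than that size, in either direction, is expected: the change from compound 3 to compound 4 is estimated at a 1.0-fold higher number from compound 3 to compound 4 (0.00 log units; within the scatter). In this assay compound 4 is expected to give 6000 nM, with a range from 2000 nM to 18000 nM.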

Compound 4, half-maximal inhibitory concentration: 6540 nM
Estimate against measurement, compound 4: 1.1-fold (0.04 log units) below; the range from low to high includes it.
By their numbers in this assay, from the lowest: compounds 3 and 4 (each within the scatter of the next); then compounds 1 and 2 (each within the scatter of the next).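

In this assay (trifluoromethyl)sulfanyl on this aromatic carbon stands level with trifluoromethyl (a 1.1-fold higher number from compound 3 to compound 4 (0.04 log units; within the scatter)), so adding the sulfur leaves the number where it was. The new group also keeps the distance from the other two groups, with methoxy (an 8.4-fold lower number from compound 2 to compound 4 (0.92 log units; beyond the scatter)) and chloro (a 6.8-fold lower number from compound 1 to compound 4 (0.83 log units; beyond the scatter)) both giving clearly higher numbers. No evidence shown explains this result.

On these data alone, what remains open is where an amine, a carboxylic acid or a longer chain on this aromatic carbon would fall, and whether the two groups would still match on another aromatic carbon of the shared core.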